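The source may hold more compounds than are shown below. What is called first, only, known or untested is meant among the compounds shown, and "the series" means these compounds.

In a functional assay on Sf9 cells for antagonist activity at histamine H2 receptor (Homo sapiens), read by scintillation counting and GTPgammaS binding, with a stated time of 90 min (on this read-out higher numbers stand for higher potency (the scale is a negative logarithm) and lower numbers for lower potency), compound 1 `CN/C(=N/C#N)NCCCc1c[nH]c(C)n1` gives only a limit, < 5. Compound 2 `N#C/N=C(/NCCCCNc1nc(N)n[nH]1)NCCSc1ccccc1` likewise gives only a limit in this assay, < 5. Both measured values sit at the same limit (the limit of < 5 in this assay, at which 2 of the 2 values shown sit), so the potency of compound 2 is not resolved as a number. Compound 3 `N#C/N=C(/NCCCNc1nccc(N)n1)NCCSc1ccccc1` carries (4-aminopyrimidin-2-yl)amino in place of ((3-amino-1H-1,2,4-triazol-5-yl)amino)methyl on a saturated chain carbon, three bonds along the chain from an amine nitrogen. Going by the values given here, no step between measured compounds is known, so the change is expected to be a number no lower from compound 2 to compound 3 (the limit leaves the size open), a step no larger than the usual scatter and without a clear direction. Compound 3 is therefore estimated at 5, between 4.3 and 5.7, and may again be reported only as a limit.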

Compound 3, negative logarithm of the antagonist equilibrium constant: < 5
Compound 3: no number, only a limit (the forecaster's own chance of this, stated with the estimate: 60%); the middle value lies on the limit itself.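

No step can be read from compound 2 to compound 3 because neither gives a number, only a limit: the limit of < 5 in this assay, at which 3 of the 3 values shown sit. As far as these compounds go, the actual potency of compound 1, compound 2 and compound 3 stays open, as does whether exchanging that group changes potency at all.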